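Para-substituent changes on the aryl sulfonamide series

This account rests on a few compounds, and the source may have more. Where it says the series, first, only, none or still open, it means among the compounds named here.

Compounds measured in a functional assay on KYSE-510 cells (Homo sapiens) for antiproliferative activity, read by crystal violet staining, with a stated time of 96 h; a lower number here means a stronger inhibitor of growth, a higher number a weaker inhibitor of growth:
compound 1 `O=S(=O)(NC1=NCCN1C(=S)SN1CCn2c1nsc2=S)c1ccccc1`: >= 20000 nM, a limit of the assay only.
compound 2 `COc1ccc(S(=O)(=O)NC2=NCCN2C(=S)SN2CCn3c2nsc3=S)cc1`: >= 20000 nM, a limit of the assay only.
compound 3 `O=S(=O)(NC1=NCCN1C(=S)SN1CCn2c1nsc2=S)c1ccc(Cl)cc1Cl`: >= 20000 nM, a limit of the assay only.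

Compound 2 stands on a limit, as do the other two values, since (the limit of >= 20000 nM in this assay, at which 3 of the 3 values shown sit). The change to compound 4 `O=S(=O)(NC1=NCCN1C(=S)SN1CCn2c1nsc2=S)c1ccc(-c2ccccc2)cc1` is phenyl in place of methoxy on an aromatic carbon, entering on an aromatic carbon para to a large group. For the measured compounds named here, the steps that bear on it, a step that the two limits leave unreadable from compound 1 to compound 2, a step that the two limits leave unreadable from compound 1 to compound 3 and a step that the two limits leave unreadable from compound 2 to compound 3, are all unreadable, so no measured step gives a size or a direction. Compound 4 is therefore expected near the same limit in this assay, at 20000 nM within 5000 nM to 60000 nM, which means an expected step of a number no higher from compound 2 to compound 4 (the limit leaves the size open).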

Compound 4, concentration for 50% growth inhibition: >= 20000 nM
Compound 4 gave a limit, no number (the forecaster's own chance of this, stated with the estimate: 75%); the middle value lies on the limit itself.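

Compound 4 against compound 2 or compound 1 gives no readable step, as each value is only a limit: the limit of >= 20000 nM in this assay, at which 4 of the 4 values shown sit.

The compounds shown leave open whether the substituent on the aryl ring changes growth inhibition at all in this assay.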